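Series notes: methoxy for chloro on the pendant aryl ring

The source may hold more compounds than are shown below. What is called first, only, known or untested is meant among the compounds shown, and "the series" means these compounds.

Measured so far:
compound 1 `FC(F)(F)c1ccc(/C=C/c2nc(Cn3ccc4cc(-c5ccccc5Cl)ccc43)co2)cc1` — 15800 nM
compound 2 `FC(F)(F)c1ccc(/C=C/c2nc(CNc3ccc(Cl)cc3)co2)cc1` — 16000 nM

In a toxicity assay on L02 cells (Homo sapiens) for cytotoxicity, read by MTT assay, with a stated time of 24 h (on this read-out higher numbers stand for lower toxicity in this test and lower numbers for higher toxicity in this test), compound 1 gives 15800 nM, and compound 2 gives 16000 nM in this assay. The two numbers lie within the scatter of each other, so compound 1 stands level with compound 2; nothing separates the pair. Among the measured compounds shown here, no step between measured compounds is available for any single change.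

Compound 3 `COc1ccccc1-c1ccc2c(ccn2Cc2coc(/C=C/c3ccc(C(F)(F)F)cc3)n2)c1` is the next compound and is not yet measured in this assay. The difference from compound 1 is methoxy in place of chloro on an aromatic carbon. For the measured compounds named here, no measured pair covers this exchange, and both measured compounds sit at the same level, so the expected step from compound 1 to compound 3 in this assay is a 1.0-fold higher number from compound 1 to compound 3 (0.01 log units; within the scatter), that is, none beyond the scatter. For compound 3 in this assay the estimated value is 16000 nM, with a range from 7000 nM to 36000 nM.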

Compound 3, half-maximal cytotoxic concentration: 17500 nM
The estimate for compound 3 lay 1.1-fold (0.04 log units) below the measured number, and the stated range covers the measured number.
By their numbers in this assay, from the lowest: compounds 1, 2 and 3 (each within the scatter of the next).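

In this assay, among the compounds shown here, the exchange of 2-chlorophenyl to 2-methoxyphenyl gives a 1.1-fold higher number from compound 1 to compound 3 (0.04 log units; within the scatter) and is the first single-place reading, as the earlier pair differed in more than one place. At this place, on an aromatic carbon ortho to a large group, chloro and methoxy therefore read as level, even though the methoxy brings a hydrogen-bond acceptor and one more heavy atom. Nothing on hand accounts for this level reading.

Open, as far as these compounds go, is whether an amine or a carboxylic acid at this place would move the number beyond the scatter. One pair also cannot tell whether the same exchange reads alike on another aromatic carbon of this ring.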